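Thiophene for Furan on a Cyclohexyl Thiosemicarbazone

The source may report more compounds than this note shows. Statements on the series, on what has been measured and on what is new or still open speak of the compounds shown alone.

Measured so far:
Compound 1, `Oc1ccc(/C=N\NC(=S)NC2CCCCC2)c(O)c1`: 56600 nM
Compound 2, `S=C(N/N=C\c1ccco1)NC1CCCCC1`: 141000 nM
Compound 3, `O=[N+]([O-])c1ccccc1/C=N\NC(=S)NC1CCCCC1`: 118000 nM

In a functional assay on MDA-MB-231 cells (Homo sapiens) for inhibition, read by WST assay, with a stated time of 48 h (on this read-out lower numbers stand for stronger inhibition and higher numbers for weaker inhibition), compound 2 gives 141000 nM, the highest of the three numbers; the gap to compound 3 lies within the scatter, while compound 1 sits beyond it with the lower number. Compound 4, `S=C(N/N=C\c1cccs1)NC1CCCCC1`, is not yet measured. It differs from compound 2 in one place: thiophen-2-yl in place of furan-2-yl on a carbon with a double bond to nitrogen. Among the compounds with values here, with no step between measured compounds to draw on, the change is expected to move the number in this assay only a little, if at all, most likely down. For compound 4 the estimate is 100000 nM, within 40000 nM to 250000 nM, a step of a 1.4-fold lower number from compound 2 to compound 4 (0.15 log units; within the scatter) that is expected to stay near the scatter.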

Compound 4, half-maximal inhibitory concentration: 58600 nM
Compound 4: middle estimate off by 1.7-fold (0.23 log units), on the high side; the range from low to high includes it.
By their numbers in this assay, from the lowest: compounds 1, 4, 3 and 2 (each within the scatter of the next, the first and the last beyond it).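

Within the data shown here, replacing furan-2-yl with thiophen-2-yl on a carbon with a double bond to nitrogen gives the first readable step at this position: in this assay the change brings a 2.4-fold lower number from compound 2 to compound 4 (0.38 log units; beyond the scatter) and is modest in size. The two groups match in heavy atoms and hydrogen-bond counts, so the exchange of ring oxygen for ring sulfur alone is enough to shift the number. Nothing measured here accounts for the step. From the compounds shown here alone, whether a carboxylic acid or an amine on the thiophen-2-yl would move the number further remains open.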